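A few compounds are considered here, and "the series" means these few. Any claim that something is new, unique, unknown or untested is made for them only; others in the source may bear on it.

In an ADME assay on BHK-21 cells (Mesocricetus auratus) for cytotoxicity, read by MTT assay, with a stated time of 72 h (on this read-out lower numbers stand for higher toxicity in this test and higher numbers for lower toxicity in this test), compound 1 (`Cc1ccccc1C1CC(c2ccc(OCc3ccccc3)cc2)=NN1c1ccc(S(N)(=O)=O)cc1`) gives 20000 nM while compound 2 (`NS(=O)(=O)c1ccc(N2N=C(c3ccc(OCc4ccccc4)cc3)CC2c2ccc(Cl)cc2)cc1`) gives 15000 nM and compound 3 (`Cc1cccc(C2CC(c3ccc(OCc4ccccc4)cc3)=NN2c2ccc(S(N)(=O)=O)cc2)c1`) gives 8000 nM in the same test. Two measured steps place the last of these: a 1.9-fold lower number from compound 2 to compound 3 (0.27 log units; within the scatter) and a 2.5-fold lower number from compound 1 to compound 3 (0.40 log units; beyond the scatter) so it stands clear of only one of the other two. Compound 4 (`NS(=O)(=O)c1ccc(N2N=C(c3ccc(OCc4ccccc4)cc3)CC2c2cccc(F)c2)cc1`) differs from compound 3 by fluoro in place of methyl on an aromatic carbon, with fluoro in place of methyl on an aromatic carbon. Among the measured compounds shown here, no measured step makes this exact exchange. The nearest exchanges, on the same phenyl group, range from a 1.3-fold lower number from compound 1 to compound 2 (0.12 log units; within the scatter) to the modest 2.5-fold lower number from compound 1 to compound 3 (0.40 log units; beyond the scatter) so no step beyond the scatter is expected in this assay here. The expected change is a 1.3-fold higher number from compound 3 to compound 4 (0.10 log units; within the scatter) in this estimate. Compound 4 is estimated at 10000 nM with an expected range from 5000 nM to 20000 nM in this test.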

Compound 4, half-maximal cytotoxic concentration: 9000 nM
The estimate for compound 4 lay 1.1-fold (0.05 log units) above the measured number; the range from low to high includes it.
By their numbers in this assay, from the lowest: compounds 3, 4, 2 and 1 (each within the scatter of the next, the first and the last beyond it).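

The exchange of methyl for fluoro on this aromatic carbon, meta to a large group, now has a direct reading in this assay: a 1.1-fold higher number from compound 3 to compound 4 (0.05 log units; within the scatter), so the two groups cannot be told apart here. With 3-fluorophenyl, a 1.7-fold lower number from compound 2 to compound 4 (0.22 log units; within the scatter), while a 2.2-fold lower number from compound 1 to compound 4 (0.35 log units; beyond the scatter), so 3-fluorophenyl, like 3-methylphenyl, stands beyond the scatter from 2-methylphenyl. As far as these compounds go, whether an amine or a carboxylic acid at this aromatic carbon would give a step beyond the scatter remains open. Nothing measured here explains these numbers.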